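Working notes on compound 3 against compounds 1 and 2

The source may report more compounds than this note shows. Statements on the series, on what has been measured and on what is new or still open speak of the compounds shown alone.

Within the data shown here, compound 1 `COc1ccccc1N1CCN(C(=O)c2nc3ccccc3s2)CC1` and compound 2 `COc1ccc(N2CCN(C(=O)c3nc4cc(Cl)ccc4s3)CC2)cc1` are the two measured members. In an ADME assay on RAW264.7 cells (Mus musculus) for cytotoxicity, read by MTT assay, with a stated time of 72 h, tested at 50 ug/mL (on this read-out higher numbers stand for more inhibition at the one concentration tested (going by the name of the read-out) and lower numbers for less inhibition), compound 1 gives 53.4%, and in this assay compound 2 gives 42.8%. Compound 2 stands lowest of the two numbers; compound 1, its nearest neighbour, lies higher by a gap beyond the usual scatter. Among the measured compounds shown here, the two differ in more than one place, so the pair yields no single step, and their values are taken only as they stand.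

Compound 3 `COc1ccccc1N1CCN(C(=O)c2nc3cc(Cl)ccc3s2)CC1` is not yet measured. Its difference from compound 2: 2-methoxyphenyl in place of 4-methoxyphenyl on an amine nitrogen in a ring. Compound 3 thus carries the 2-methoxyphenyl of compound 1 together with the rest of compound 2. For the measured compounds named here, no step between measured compounds covers this change. An upward step from compound 2 is expected in this assay, since compound 1 with the same 2-methoxyphenyl gives 53.4%, but a step no larger than the scatter would not surprise. The expected step in this assay is a number 7.2 percentage points higher from compound 2 to compound 3 (within the scatter). Compound 3 is expected to give 50%, within 36% to 64%.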

Compound 3, a percentage reported as inhibition, at one concentration (the size of the read-out at that concentration, not a potency): 63.4%
Beside the measured number, compound 3's estimate is 13.4 percentage points below it; measured number inside the range.
By their numbers in this assay, from the lowest: compound 2; then compounds 1 and 3 (each within the scatter of the next).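

Working notes on the result for compound 3

In this assay, among these compounds, 2-methoxyphenyl in place of 4-methoxyphenyl on an amine nitrogen in a ring gives a number 20.6 percentage points higher from compound 2 to compound 3 (beyond the scatter), the first single-place comparison at this position, and it shows that with the rest of the structure held constant, this exchange alone moves the read-out beyond the usual scatter. The other single-place comparison, chloro in place of hydrogen on an aromatic carbon, gives a number 10 percentage points higher from compound 1 to compound 3 (within the scatter), so on the 2-methoxyphenyl compounds the chloro change cannot be told apart from repeat-to-repeat variation in this read-out. Nothing available bears on why the exchange of methoxyphenyl groups shifts the number, and no cause can be assigned to it.

Whether the same exchange gives a step of similar size on the core of compound 1 remains open, since the series shown holds only one such pair, on the chloro-bearing core. Also open, going by these compounds, is how this read-out responds when an unsubstituted phenyl, or a phenyl carrying a hydroxyl or an amine in place of the methoxy group, stands on the same ring nitrogen.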